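Thiosemicarbazone series: removing the para-fluoro on the aryl

The compounds below may be only part of what the source reports. "The series", "measured", "known", "first", "only" and "open" are said of these compounds alone.

Measured in a functional assay on T98G cells (Homo sapiens) for cytotoxicity, read by MTT assay, with a stated time of 48 h; on this read-out lower numbers stand for stronger inhibition and higher numbers for weaker inhibition:
compound 1 `C/C(=N/NC(=S)Nc1ccccc1Cl)c1ccccn1`: 1.1 nM
compound 2 `C/C(=N\NC(=S)Nc1ccccc1)c1ccccn1`: 6.81 nM
compound 3 `C/C(=N/NC(=S)Nc1ccc(F)cc1)c1ccccn1`: 17 nM

Compound 3 stands at the highest of the three numbers in this assay. Its nearest neighbour is compound 2, whose number is lower by a margin beyond the scatter, and compound 1 is furthest, with a number lower by a much larger margin.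

Compound 4 `C/C(=N/NC(=S)Nc1ccccc1)c1ccccn1` has not been measured. Compared with compound 3 it shows (hydrogen in place of fluoro on an aromatic carbon). Compound 4 thus carries the same unsubstituted aryl as compound 2; the two are drawn with different geometry about the hydrazone carbon-nitrogen double bond, so compound 2 serves only as a rough reference for the bare phenyl.

For the measured compounds named here, no measured pair differs in this one place, so the size of the step must be guessed. Because compound 2, the unsubstituted aryl, gives 6.81 nM while compound 3 gives 17 nM, the change is expected to lower the number somewhat, by a step of a 2.1-fold lower number from compound 3 to compound 4 (0.33 log units; beyond the scatter) that may or may not clear the scatter. Compound 4 is accordingly estimated at 8 nM, within a range of 3 nM to 25 nM.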

Compound 4, half-maximal inhibitory concentration: 6.81 nM
The estimate for compound 4 lay 1.2-fold (0.07 log units) above the measured number, and the stated range covers the measured number.
By their numbers in this assay, from the lowest: compound 1; then compounds 2 and 4 (each within the scatter of the next); then compound 3.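

In this assay, hydrogen in place of fluoro on an aromatic carbon, para to a large group, gives a 2.5-fold lower number from compound 3 to compound 4 (0.40 log units; beyond the scatter), so this position now has a directly measured step, and it runs against the fluoro group. Hydrogen in place of chloro gives a 6.2-fold higher number from compound 1 to compound 4 (0.79 log units; beyond the scatter), so the bare phenyl falls on opposite sides of the two halogen compounds, and halogen on the aryl does not move the number in one direction across this small set. The drawn geometry at the hydrazone double bond shows no change at the digits printed from compound 2 to compound 4 (within the scatter), and no effect of geometry can be read from this pair, because the identical digits leave it unclear whether two separate isomers are being compared, the only recorded difference being this: the fact that compounds 2 and 4 differ only in the configuration as drawn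

Still open, from the compounds shown here alone, is whether a methoxy group or an amine on that same aromatic carbon would lower the number further or raise it as fluoro does. The compounds shown also leave open whether fluoro placed where compound 1 carries its chloro would follow chloro, and how a carboxylic acid on the aryl would behave.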